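Methyl on the hydroxymethyl group of compound 1

The source may hold more compounds than are shown below. What is called first, only, known or untested is meant among the compounds shown, and "the series" means these compounds.

Compound 1 (`CC1=CCC[C@](C)(CC/C(C)=C/CC2=C(O)C(=O)C=C(N[C@@H](CO)C(=O)O)C2=O)[C@@H]1C`) is the starting point in an ADME assay on L1210 cells (Mus musculus) for cytotoxicity, with a stated time of 48 h; a lower number here means a stronger inhibitor, a higher number a weaker inhibitor. Compound 1 gives > 10 ug/mL, which is a limit and not a number. Compound 2 (`C=C1[C@H](C)CCC[C@]1(C)CC/C(C)=C/CC1=C(O)C(=O)C=C(N[C@@H](CO)C(=O)O)C1=O`) gives > 10 ug/mL, which is also a limit.

Going by the values given here, the only measured step, a step that the two limits leave unreadable from compound 1 to compound 2, has no readable size, and the limit of > 10 ug/mL in this assay, at which 2 of the 2 values shown sit, describes both compounds. Neither compound therefore has an exact value to anchor the series.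

Compound 3 (`CC1=CCC[C@](C)(CC/C(C)=C/CC2=C(O)C(=O)C=C(N[C@H](C(=O)O)[C@H](C)O)C2=O)[C@@H]1C`) differs from compound 1 by methyl in place of hydrogen on a saturated chain carbon bound to an oxygen on a saturated carbon and a saturated chain carbon. Cut one bond further out, the same difference reads hydroxymethyl to 1-hydroxyethyl. The step from compound 1 to compound 2 lies elsewhere in the structure and gives no measured size for this change.

The expectation therefore rests only on compound 1 and compound 2 sharing (the limit of > 10 ug/mL in this assay, at which 2 of the 2 values shown sit). The expected step, a step that the limit leaves unreadable from compound 1 to compound 3, is none beyond the scatter, and no direction can be assigned. A further limit is the most likely report in this assay. For compound 3 the estimated value is 15 ug/mL, with an expected range of 8 ug/mL to 40 ug/mL.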

Compound 3, half-maximal inhibitory concentration: > 10 ug/mL
Compound 3 ended at the assay's limit; the forecaster's own chance of this, stated with the estimate: 85%; the middle value lies beyond the limit too.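

The step from compound 1 to compound 3 cannot be read, and compound 3 adds no exact value to the series: the limit of > 10 ug/mL in this assay, at which 3 of the 3 values shown sit.

The compounds shown leave open what size of effect, if any, the change from hydroxymethyl to 1-hydroxyethyl has in this assay, since compound 1, compound 2 and compound 3 all lack an exact value to compare.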